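Amide variation in a three-compound series; compound 4 expected

A few compounds are considered here, and "the series" means these few. Any claim that something is new, unique, unknown or untested is made for them only; others in the source may bear on it.

Measured so far in an assay on isolated protein for inhibition of aldehyde dehydrogenase 1A1 (Homo sapiens), read by spectrophotometry, tested at 10 uM; a lower number here means less inhibition, a higher number more inhibition at the concentration tested (going by the name of the read-out):
compound 1 `Cc1cccc(Cn2c(CN3CCN(C(=O)c4ccc([N+](=O)[O-])cc4)CC3)nc3ccccc32)c1` gives 24.3%
compound 2 `COc1ccc(C(=O)N2CCN(Cc3nc4ccccc4n3Cc3cccc(C)c3)CC2)cc1` gives 55.5%
compound 3 `Cc1cccc(Cn2c(CN3CCN(C(=O)CC(C)C)CC3)nc3ccccc32)c1` gives 71.4%

Compound 3 stands highest of the three in this assay, the nearest being compound 2 and the furthest compound 1, both steps to it beyond the scatter. The measured steps all concern the group on the carbonyl carbon: a number 31.2 percentage points higher from compound 1 to compound 2 (beyond the scatter), a number 47.1 percentage points higher from compound 1 to compound 3 (beyond the scatter) and a number 15.9 percentage points higher from compound 2 to compound 3 (beyond the scatter). Each of them exchanges an aromatic group for another aromatic group or for isobutyl.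

Compound 4 `Cc1cccc(Cn2c(CN3CCN(C(=O)C4CCC4)CC3)nc3ccccc32)c1` differs from compound 3 by cyclobutyl in place of isobutyl on a carbonyl carbon. Going by the values given here, no measured step exchanges one alkyl group for another, so the measured steps bear on this change only by showing that the non-aromatic amide of compound 3 sits highest; none of them speaks to the shape of that alkyl group. The expectation is therefore a step of no size beyond the scatter, with the estimate of a number 3.4 percentage points lower from compound 3 to compound 4 (within the scatter). Compound 4 is expected at 68%, within 50% to 85%.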

Compound 4, a percentage reported as inhibition, at one concentration (the size of the read-out at that concentration, not a potency): 69.1%
Compound 4: the middle estimate sits 1.1 percentage points below what was measured, within the range that was stated.
By their numbers in this assay, from the lowest: compound 1; then compound 2; then compounds 4 and 3 (each within the scatter of the next).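

In this assay the exchange of one alkyl group for another on the carbonyl carbon gives a number 2.3 percentage points lower from compound 3 to compound 4 (within the scatter) and so, within the scatter, a ring in that alkyl group makes no difference to the read-out. Cyclobutyl in place of the aromatic groups gives a number 13.6 percentage points higher from compound 2 to compound 4 (beyond the scatter) and a number 44.8 percentage points higher from compound 1 to compound 4 (beyond the scatter) as its two steps, so the advantage seen for the open-chain isobutyl of compound 3 over these aromatic amides also holds for a cyclic alkyl group. No evidence on the cause of these steps is available.

Still open, from the compounds shown here alone, is how the read-out responds on the carbonyl carbon to a methyl group, a longer chain such as n-hexyl or a larger ring such as cyclohexyl. Also open, going by these compounds, is the effect of an amine or a carboxylic acid on the alkyl group.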